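The source may hold more compounds than are shown below. What is called first, only, known or untested is meant among the compounds shown, and "the series" means these compounds.

Compound 1 `Cc1cccc(NC(=O)Nc2cccc(CNc3ncnc4ccccc34)c2)c1`: 30200 nM
Compound 2 `CC(C)(C)c1ccc(NC(=O)Nc2cccc(CNc3ncnc4ccccc34)c2)cc1`: 7470 nM

Among the compounds with values here, in a functional assay on MGC-803 cells (Homo sapiens) for antiproliferative activity, read by MTT assay (on this read-out lower numbers stand for stronger inhibition and higher numbers for weaker inhibition), compound 2 gives 7470 nM, the lowest of the two numbers in hand; the only neighbour, compound 1, gives 30200 nM. Within the data shown here, the single measured step, a 4.0-fold lower number from compound 1 to compound 2 (0.61 log units; beyond the scatter), is modest and beyond the scatter. Compound 3 `O=C(Nc1ccc([N+](=O)[O-])cc1)Nc1cccc(CNc2ncnc3ccccc23)c1` differs from compound 2 by nitro in place of tert-butyl on an aromatic carbon. Among the measured compounds shown here, no measured step involves a nitro group, so nothing in hand bears directly on this change; the one step, a 4.0-fold lower number from compound 1 to compound 2 (0.61 log units; beyond the scatter), only shows that exchanging the substituent on this ring can shift the number modestly, without saying in which direction a nitro would act. For compound 3 the expected step is therefore a 1.2-fold higher number from compound 2 to compound 3 (0.08 log units; within the scatter), a small change not beyond the scatter, with wide uncertainty. Compound 3 is estimated at 9000 nM, with a range from 2500 nM to 40000 nM.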

Compound 3, half-maximal inhibitory concentration: 9420 nM
Estimate against measurement, compound 3: 1.0-fold (0.02 log units) below; measured number inside the range.
By their numbers in this assay, from the lowest: compounds 2 and 3 (each within the scatter of the next); then compound 1.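

In this assay, nitro in place of tert-butyl on this aromatic carbon gives a 1.3-fold higher number from compound 2 to compound 3 (0.10 log units; within the scatter), so two groups that share no heavy atom and differ in their hydrogen-bond acceptor count cannot be told apart here. The step of a 3.2-fold lower number from compound 1 to compound 3 (0.51 log units; beyond the scatter), with 4-nitrophenyl in place of 3-methylphenyl, shows that the gain seen with 4-(tert-butyl)phenyl is not confined to that one group. No measurement in hand accounts for why these two groups read alike.

Both steps from compound 1 change the group and its place on the ring together, so a methyl on the same aromatic carbon as the tert-butyl of compound 2 would be needed to separate the two. Going by these compounds, whether an amine or a carboxylic acid there would also stay within the scatter of compound 2 remains open.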